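The source may hold more compounds than are shown below. What is called first, only, known or untested is meant among the compounds shown, and "the series" means these compounds.

Readings in an ADME assay on microsomes from liver (Homo sapiens) for metabolic stability, read by LC-MS, with a stated time of 10 min (a lower number here means that less of the compound is left, a higher number that more of the compound is left), so far:

compound 1, `CN(C[C@H]1Cc2c(cccc2N2CCN(C3CC3)CC2)CN1)[C@H]1CCCc2cccnc21`: 15.5%
compound 2, `CN(C[C@H]1Cc2c(cccc2N2C[C@@H]3C[C@H]2CN3)CN1)[C@H]1CCCc2cccnc21`: 100%
compound 3, `CN(C[C@H]1Cc2c(cccc2N2CCNCC2)CN1)[C@H]1CCCc2cccnc21`: 99.7%

Compound 3 sits at the second highest of the three numbers, but its nearest neighbour is compound 2, and that pair lies within the scatter: a number 0.3 percentage points lower from compound 2 to compound 3 (within the scatter). For the measured compounds named here, the only large steps run from compound 1, which gives the lowest value; against compound 3 the step is a number 84.2 percentage points higher from compound 1 to compound 3 (beyond the scatter), and against compound 2 it is a number 84.5 percentage points higher from compound 1 to compound 2 (beyond the scatter).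

Compound 4, `CCN1CCN(c2cccc3c2C[C@H](CN(C)[C@H]2CCCc4cccnc42)NC3)CC1`, is next to be measured. Its change from compound 3 is ethyl in place of hydrogen on an amine nitrogen in a ring. Going by the values given here, the step that bears on it most directly is the one from compound 1 to compound 3, which removed a cyclopropyl from this same ring nitrogen and raised the number by a large margin. Compound 4 puts an alkyl back onto that nitrogen, though ethyl rather than cyclopropyl, so the step is not the plain reverse. The step from compound 2 to compound 3 does not speak to the change. A downward step in this assay is therefore expected for compound 4, of uncertain size: a number 44.7 percentage points lower from compound 3 to compound 4 (beyond the scatter). The estimate for compound 4 is 55%, between 15% and 100%.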

Compound 4, percent of the compound remaining: 0%
For compound 4 the middle estimate is 55 percentage points above the measured one; the whole stated range lies above it.
By their numbers in this assay, from the lowest: compound 4; then compound 1; then compounds 3 and 2 (each within the scatter of the next).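

In this assay, the step of a number 99.7 percentage points lower from compound 3 to compound 4 (beyond the scatter) shows that ethyl alone on this amine nitrogen in the ring is enough to remove the high reading, so the earlier loss is not peculiar to cyclopropyl. Ethyl also brings no recovery from the cyclopropyl level, since the step of a number 15.5 percentage points lower from compound 1 to compound 4 (beyond the scatter) is a further, modest fall beyond the scatter. With the step of a number 100 percentage points lower from compound 2 to compound 4 (beyond the scatter) as well, the two compounds with an unsubstituted ring amine, compound 2 and compound 3, stand far from the two with an alkyl group on that nitrogen, compound 1 and compound 4, and no compound shown goes against this split.

The compounds shown give no measurement that accounts for this split.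

Open, going by these compounds, is how a methyl, an acetyl or a 2-hydroxyethyl group on this nitrogen would read in this assay, and whether an ethyl on the free nitrogen of the bridged group in compound 2 would give the same fall.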